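This account rests on a few compounds, and the source may have more. Where it says the series, first, only, none or still open, it means among the compounds named here.

Among the compounds with values here, in a functional assay on A549 cells (Homo sapiens) for inhibition, read by MTT assay, with a stated time of 72 h (on this read-out lower numbers stand for stronger inhibition and higher numbers for weaker inhibition), compound 1 `C=CC(=O)Nc1cc(Nc2nc3c(c(-c4cn(C)c5ccccc45)n2)CSCC3)c(OC)cc1N(C)CCN(C)C` reads 506 nM and compound 2 `C/C=C\C(=O)Nc1cc(Nc2nc3c(c(-c4cn(C)c5ccccc45)n2)CSCC3)c(OC)cc1N(C)CCN(C)C` reads 6860 nM as the higher of the only two numbers so far. Compound 3 `CCC/C=C\C(=O)Nc1cc(Nc2nc3c(c(-c4cn(C)c5ccccc45)n2)CSCC3)c(OC)cc1N(C)CCN(C)C` differs from compound 2 by ethyl in place of hydrogen on a saturated chain carbon bound to a double-bonded chain carbon and this means ethyl in place of hydrogen on a saturated chain carbon bound to a double-bonded chain carbon, so prop-1-en-1-yl becomes pent-1-en-1-yl. Within the data shown here, only one measured step bears on this change. It is a 14-fold higher number from compound 1 to compound 2 (1.13 log units; beyond the scatter) with prop-1-en-1-yl in place of vinyl on a carbonyl carbon, and that step was large. One case cannot show whether a longer chain keeps raising the number, so a smaller step in the same direction is expected. The estimate is a 1.3-fold higher number from compound 2 to compound 3 (0.12 log units; within the scatter) and it is not expected to stand clearly beyond the scatter. Compound 3 is expected to read 9000 nM with an estimated range from 3500 nM to 22000 nM as its likely span.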

Compound 3, half-maximal inhibitory concentration: 571 nM
Compound 3: middle estimate off by 16-fold (1.20 log units), on the high side; measured number outside the range, below it.
By their numbers in this assay, from the lowest: compounds 1 and 3 (each within the scatter of the next); then compound 2.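

In this assay, ethyl in place of hydrogen on this saturated chain carbon gives a 12-fold lower number from compound 2 to compound 3 (1.08 log units; beyond the scatter), so at this position a longer chain does not keep raising the number. Pent-1-en-1-yl in place of vinyl on the carbonyl carbon gives a 1.1-fold higher number from compound 1 to compound 3 (0.05 log units; within the scatter), which lies within the scatter, so among these three compounds only compound 2, with prop-1-en-1-yl, reads clearly weaker. No measurement shown here gives a reason for this uneven result.

As far as these compounds go, three compounds cannot show how the number changes with chain length in general, so but-1-en-1-yl and longer chains such as hept-1-en-1-yl remain open. From the compounds shown here alone, it is also open whether an amine, such as dimethylamino, in place of the ethyl would read close to compound 3 or close to compound 2.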